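Removing the silicon group from compound 3

This account rests on a few compounds, and the source may have more. Where it says the series, first, only, none or still open, it means among the compounds named here.

Compound 1 `COc1ccccc1-c1cn(C[C@H](O)[C@H]2OC(=O)C(OCc3ccccc3)=C2OCc2ccccc2)nn1`: > 100000 nM (a limit of the assay, not a number)
Compound 2 `O=C1O[C@H]([C@@H](O)Cn2cc(-c3cc(F)cc(F)c3)nn2)C(OCc2ccccc2)=C1OCc1ccccc1`: 40800 nM
Compound 3 `C[Si](C)(C)c1cn(C[C@H](O)[C@H]2OC(=O)C(OCc3ccccc3)=C2OCc2ccccc2)nn1`: 22300 nM

All three compounds were tested in a functional assay on HeLa cells (Homo sapiens) for antiproliferative activity, read by MTT assay, with a stated time of 72 h; a higher number here means a weaker inhibitor, a lower number a stronger inhibitor. Compound 3 cannot be told apart from compound 2, as a 1.8-fold lower number from compound 2 to compound 3 (0.26 log units; within the scatter) lies within the usual scatter. Both sit on the stronger side of compound 1, shown by an at least 4.4-fold lower number from compound 1 to compound 3 (0.65 log units; beyond the scatter) and an at least 2.4-fold lower number from compound 1 to compound 2 (0.38 log units; beyond the scatter).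

The next compound is compound 4 `O=C1O[C@H]([C@@H](O)Cn2ccnn2)C(OCc2ccccc2)=C1OCc1ccccc1`, with a hydrogen atom in place of a group of 4 heavy atoms (3 carbon, 1 silicon; no ring), on an aromatic carbon. The change is on an aromatic carbon of the five-membered aromatic ring with 3 nitrogen, the same carbon that varies across the three measured compounds. Among the compounds with values here, no measured step leaves this carbon bare, so the evidence is indirect. Three steps show that the group here can shift the number: an at least 2.4-fold lower number from compound 1 to compound 2 (0.38 log units; beyond the scatter), an at least 4.4-fold lower number from compound 1 to compound 3 (0.65 log units; beyond the scatter) and a 1.8-fold lower number from compound 2 to compound 3 (0.26 log units; within the scatter). All three values are weak, and compound 3 is at the strong end of them, so a modest move towards a higher number, meaning a weaker inhibitor, is the likelier outcome. The expected step is a 2.0-fold higher number from compound 3 to compound 4 (0.30 log units; within the scatter). For compound 4 the estimated value is 45000 nM, with an expected range of 15000 nM to 120000 nM.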

Compound 4, half-maximal inhibitory concentration: > 100000 nM
Compound 4: no number, only a limit; the forecaster's own chance of this, stated with the estimate: 35%; middle value at least 2.2-fold (0.34 log units) away from the limit.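

Within the data shown here, until now, every group on this aromatic carbon of the five-membered aromatic ring with 3 nitrogen had been compared only with another group, and compound 4 adds the first comparison with plain hydrogen. In this assay, hydrogen is clearly worse than either of the two better groups, as shown by an at least 4.4-fold higher number from compound 3 to compound 4 (0.65 log units; beyond the scatter) and by an at least 2.4-fold higher number from compound 2 to compound 4 (0.38 log units; beyond the scatter), so a group on this carbon can matter, and the ring-free silicon group shows that it need not be an aromatic ring. Compound 4 gives > 100000 nM, a limit of the assay and not a number, and compound 1 stops at the same limit, so the step between them cannot be read and having a group here is not enough on its own, since the 2-methoxyphenyl of compound 1 goes against that idea: the limit of > 100000 nM in this assay, at which 2 of the 4 values shown sit.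

The compounds shown do not tell whether the silicon atom itself counts, which a tert-butyl group on the same carbon would test. They also leave open how an amine, a carboxylic acid or a longer carbon chain at this position would behave, and whether any group here can go beyond the weak values seen so far.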